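Swapping the last ring chloro on a weak growth inhibitor

The source may report more compounds than this note shows. Statements on the series, on what has been measured and on what is new or still open speak of the compounds shown alone.

Compound 1 `O=S(=O)(/C=C/c1ccc(Cl)cc1Cl)Cc1ccc(Nc2ncnc3cc(Cl)ccc23)cc1`: 59000 nM
Compound 2 `O=S(=O)(/C=C/c1ccc(F)cc1Cl)Cc1ccc(Nc2ncnc3cc(Cl)ccc23)cc1`: > 100000 nM
Compound 3 `O=S(=O)(/C=C/c1ccc(F)cc1F)Cc1ccc(Nc2ncnc3cc(Cl)ccc23)cc1`: not yet measured

In a functional assay on HT-29 cells (Homo sapiens) (a higher number here means a weaker inhibitor of growth, a lower number a stronger inhibitor of growth), compound 1 gives 59000 nM. For compound 2 the assay reports only a limit, > 100000 nM, and no number is known for it.

The next step, to compound 3, is fluoro in place of chloro on an aromatic carbon, which turns 2-chloro-4-fluorophenyl into 2,4-difluorophenyl. For the measured compounds named here, one measured step bears on this, as it is the same kind of replacement: an at least 1.6-fold higher number from compound 1 to compound 2 (0.22 log units; that floor lies within the scatter). Its size is only a floor and lies within the scatter, so it shows no firm change. Any estimate here also rests against (the limit of > 100000 nM in this assay, at which 1 of the 2 values shown sits). In this assay no step beyond the scatter is therefore expected, with at most a slight lean towards a higher number. The expected step is a number no higher from compound 2 to compound 3 (the limit leaves the size open). The estimated value for compound 3 is 100000 nM, with an expected range from 50000 nM to 200000 nM. The assay may well report only a limit again.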

Compound 3, concentration for 50% growth inhibition: > 100000 nM
Compound 3: a limit, no number (the forecaster's own chance of this, stated with the estimate: 65%); the middle value lies on the limit itself.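

In this assay compound 3 gives > 100000 nM, which is a limit of the assay and not a number. Replacing both chloro groups, the change from 2,4-dichlorophenyl to 2,4-difluorophenyl gives an at least 1.6-fold higher number from compound 1 to compound 3 (0.22 log units; that floor lies within the scatter), so even the full exchange yields only a floor and shows no firm change. The step from 2-chloro-4-fluorophenyl to 2,4-difluorophenyl cannot be read, and the swap on the carbon ortho to a large group stays without a measured size, because the values have reached the limit of the assay: the limit of > 100000 nM in this assay, at which 2 of the 3 values shown sit.

On these data alone, whether compound 2 and compound 3 differ at all stays open, since neither carries a number. Also open, as far as these compounds go, is what a methoxy group or an amine on this aromatic carbon would do, and whether any such group would bring growth inhibition into a range that this assay can report as a number.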